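This account rests on a few compounds, and the source may have more. Where it says the series, first, only, none or still open, it means among the compounds named here.

Measured so far in a functional assay on the whole organism (strain Wistar) for inhibition, with Rattus norvegicus as the target, read by paw edema, with stated times of 60 min and 24 h, at a dose of 100 mg/kg by the oral route; on this read-out higher numbers stand for more inhibition at the one dose given (going by the name of the read-out) and lower numbers for less inhibition:
compound 1, `COc1cc2c(cc1OC)C(CC(=O)O)CC2`: 26.7%
compound 2, `CCCCCCNC(=O)CC1CCc2cc(OC)c(OC)cc21`: 45.5%

Compound 2 stands highest of the two numbers. For the measured compounds named here, the only measured step, a number 18.8 percentage points higher from compound 1 to compound 2 (beyond the scatter), changes the substituent on the carbonyl carbon and not the group on the amide-type nitrogen. Compound 3, `COc1cc2c(cc1OC)C(CC(=O)NC1CCCC1)CC2`, differs from compound 2 by cyclopentyl in place of hexyl on an amide-type nitrogen. Going by the values given here, no measured step varies the group on the amide-type nitrogen, so the only anchor is compound 2 at 45.5%. For compound 3 a change of a number 3.5 percentage points lower from compound 2 to compound 3 (within the scatter) is expected, none beyond the scatter. Compound 3 is therefore estimated at 42%, within 25% to 60%.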

Compound 3, a percentage reported as inhibition, in the whole organism at one dose (the size of the read-out at that dose, not a potency): 46.7%
The estimate for compound 3 lay 4.7 percentage points below the measured number; measured number inside the range.
By their numbers in this assay, from the lowest: compound 1; then compounds 2 and 3 (each within the scatter of the next).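

In this assay, cyclopentyl in place of hexyl on the amide-type nitrogen gives a number 1.2 percentage points higher from compound 2 to compound 3 (within the scatter), so a five-membered carbon ring and an open hexyl chain are not told apart at this position. Cyclopentylamino in place of hydroxy on the carbonyl carbon gives a number 20 percentage points higher from compound 1 to compound 3 (beyond the scatter), so the step away from hydroxy beyond the scatter now holds for two different amino groups, not for hexylamino alone. No measurement given here accounts for these results. Still open, on these data alone, is how a phenyl or benzyl group on that nitrogen, or a shorter chain such as ethyl, would read.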